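The source may report more compounds than this note shows. Statements on the series, on what has been measured and on what is new or still open speak of the compounds shown alone.

Compound 1 `COc1ccc(N2NC3=CC[C@@H](OC)O[C@@]3(c3ccccc3)CC2=O)cc1` is the weaker of the two measured compounds in a functional assay on SK-BR-3 cells (Homo sapiens) for inhibition, read by sulforhodamine B assay, with a stated time of 48 h; on this read-out higher numbers stand for weaker inhibition and lower numbers for stronger inhibition: compound 1 gives 8400 nM, the highest of the two numbers shown. Compound 2 `COc1cc(OC)cc(N2NC3=CC[C@@H](OC)O[C@@]3(c3ccncc3)CC2=O)c1` differs from compound 1 in several places at once. In this assay, within the data shown here, compound 2 gives 210 nM, a lower number; as the two compounds differ in several places, the values alone show only that compound 2 inhibits more strongly, not which change carries it. Compound 3 `CO[C@@H]1CC=C2NN(c3cncnc3)C(=O)C[C@]2(c2ccccc2)O1` has not yet been measured. It differs from compound 1 by a single change, (pyrimidin-5-yl in place of 4-methoxyphenyl on an amide-type nitrogen in a ring). Among the measured compounds shown here, no measured pair isolates this change, so there is no direct guide to its size or direction. On the numbers at hand, compound 3 is expected to stay close to compound 1, with the step of a 1.4-fold higher number from compound 1 to compound 3 (0.15 log units; within the scatter) estimated to fall within or only slightly beyond the usual scatter. Compound 3 is therefore estimated at 12000 nM, with a plausible range from 3000 nM to 50000 nM.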

Compound 3, half-maximal inhibitory concentration: 5300 nM
Compound 3: middle estimate off by 2.3-fold (0.35 log units), on the high side; the range from low to high includes it.
By their numbers in this assay, from the lowest: compound 2; then compounds 3 and 1 (each within the scatter of the next).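

In this assay, among these compounds, this is the first comparison that isolates the group on the amide-type nitrogen in a ring, and it gives (a 1.6-fold lower number from compound 1 to compound 3 (0.20 log units; within the scatter)), a step within the scatter. With the rest of the core unchanged, the values for pyrimidin-5-yl and 4-methoxyphenyl at this position cannot be told apart, even though the two groups differ in ring atoms and in counted hydrogen-bond acceptors. Nothing available explains this result.

The compounds shown leave open whether a different kind of group at this position, such as a phenyl ring carrying an aminomethyl group or a carboxylic acid, would give a step beyond the scatter. They also leave open which of the several differences between compound 1 and compound 2 carries the stronger inhibition of compound 2.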